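The compounds below may be only part of what the source reports. "The series", "measured", "known", "first", "only" and "open" are said of these compounds alone.

In a functional assay on HCC827 cells (Homo sapiens) for cytotoxicity, read by MTT assay, with a stated time of 72 h (on this read-out lower numbers stand for stronger inhibition and higher numbers for weaker inhibition), compound 1 `Cc1cc(C)cc(-n2c(Nc3ccccc3)nc3cnc(Nc4ccc(N5CCN(C)CC5)cc4)nc32)c1` gives 1 nM and compound 2 `c1ccc(Nc2ncc3nc(Nc4ccccc4)n(C4CCCC4)c3n2)cc1` gives 2.7 nM. Compound 3 `Cc1cccc(Nc2nc3cnc(Nc4ccc(N5CCN(C)CC5)cc4)nc3n2C2CCCC2)c1` reads < 0.01 nM, which is a limit and not a number: the limit of < 0.01 nM in this assay, at which 1 of the 3 values shown sits. Compound 4 `CN1CCN(c2ccc(Nc3ncc4nc(Nc5ccc(Br)cc5F)n(C5CCCC5)c4n3)cc2)CC1` differs from compound 3 by 4-bromo-2-fluorophenyl in place of 3-methylphenyl on a nitrogen on an aromatic ring, with 4-bromo-2-fluorophenyl in place of 3-methylphenyl on a nitrogen on an aromatic ring. Going by the values given here, no measured step between compounds differing in one place is available, so the size of this change in this assay remains open. Only a move towards weaker inhibition can be read clearly against a limit. Compound 1 at 1 nM shows that higher readings occur in the series. The expected change is an at least 10-fold higher number from compound 3 to compound 4 (1.00 log units; beyond the scatter). For compound 4 the estimated value is 0.1 nM, with an expected range of 0.005 nM to 3 nM.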

Compound 4, half-maximal inhibitory concentration: 2.3 nM
Compound 4: the middle estimate sits 23-fold (1.36 log units) below what was measured; the measured number falls inside the stated range.
By their numbers in this assay, from the lowest: compound 1; then compounds 4 and 2 (each within the scatter of the next). At a limit, below all of these: compound 3.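

At this place, on a nitrogen on an aromatic ring, 4-bromo-2-fluorophenyl in place of 3-methylphenyl gives an at least 230-fold higher number from compound 3 to compound 4 (2.36 log units; beyond the scatter) in this assay. Going by these compounds alone, the reading in this assay therefore responds to the group at this place by more than the scatter, which no earlier pair could show. The step has a lower bound and no exact size, as compound 3 stands at a limit: the limit of < 0.01 nM in this assay, at which 1 of the 4 values shown sits.

From the compounds shown here alone, whether the bromine or the fluorine carries the step stays open. Going by these compounds, how a carboxylic acid or an amine on this phenyl ring would read also stays open.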